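This account rests on a few compounds, and the source may have more. Where it says the series, first, only, none or still open, it means among the compounds named here.

Compound 1 `Cc1cccc(Nc2nccc(-c3ccc(Br)cc3)n2)c1`: in an assay on isolated protein for inhibition of phosphatidylinositol 4,5-bisphosphate 3-kinase catalytic subunit beta isoform (Homo sapiens) (a higher number here means a weaker inhibitor, a lower number a stronger inhibitor), compound 1 gives > 1000 nM, a limit of the assay.
Compound 2 `COc1ccc(-c2ccnc(Nc3ccc(Cl)cc3Cl)n2)cc1`: compound 2 gives 839 nM.

For the measured compounds named here, compound 2 holds the only numerical value shown in this assay. The other value shown is a limit: the limit of > 1000 nM in this assay, at which 1 of the 2 values shown sits. Compound 3 `Clc1ccc(Nc2nccc(-c3ccc(Br)cc3)n2)c(Cl)c1` differs from compound 2 by bromo in place of methoxy on an aromatic carbon. Going by the values given here, no step between measured compounds is available to size this change. Compound 1 also carries bromo and gives > 1000 nM, a limit of the assay. The step expected from compound 2 to compound 3 is a weakening somewhat beyond the scatter a 1.8-fold higher number from compound 2 to compound 3 (0.25 log units; within the scatter). Compound 3 is estimated at 1500 nM, within the range 400 nM to 5000 nM.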

Compound 3, half-maximal inhibitory concentration: 673 nM
Compound 3: middle estimate off by 2.2-fold (0.35 log units), on the high side; the range from low to high includes it.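

At this place, on an aromatic carbon para to a large group, bromo in place of methoxy gives in this assay a 1.2-fold lower number from compound 2 to compound 3 (0.10 log units; within the scatter). Losing the methoxy, and with it a hydrogen-bond acceptor, therefore leaves the number inside the scatter, so the two groups cannot be told apart here. Compound 2 and compound 3 both give true numbers, so this step can be read, and the one remaining value is a limit: the limit of > 1000 nM in this assay, at which 1 of the 3 values shown sits.

Still open, on these data alone, is whether an amine, a carboxylic acid or a longer chain at this place would move the number beyond the scatter. Why methoxy and bromo match also remains unknown.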